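This account rests on a few compounds, and the source may have more. Where it says the series, first, only, none or still open, it means among the compounds named here.

For the measured compounds named here, in an ADME assay on microsomes from liver (Homo sapiens) for metabolic stability, read by LC-MS, with a stated time of 10 min (on this read-out lower numbers stand for a less stable compound and higher numbers for a more stable compound), compound 2 (`CCCN(C[C@H]1Cc2c(cccc2N2CCNCC2)CN1)[C@H]1CCCc2cccnc21`) gives 100% and stands highest of the two numbers so far, beyond the scatter from compound 1 (`CN(C[C@H]1Cc2c(cccc2N2CCN3CCC[C@@H]3C2)CN1)[C@H]1CCCc2cccnc21`), which gives 52.2% here. Compound 3 (`CN(C[C@H]1Cc2c(cccc2N2CCNCC2)CN1)[C@H]1CCCc2cccnc21`) departs from compound 2 by hydrogen in place of ethyl on a saturated chain carbon bound to an amine nitrogen as hydrogen in place of ethyl on a saturated chain carbon bound to an amine nitrogen, which also reads as propyl to methyl. Going by the values given here, no measured step isolates this change. A moderate fall in this assay is expected, beyond the scatter, because compound 1, which also carries methyl, gives 52.2% in this test. The expected change is a number 18 percentage points lower from compound 2 to compound 3 (beyond the scatter) in size. Compound 3 is estimated at 82% with a range from 60% to 100% expected.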

Compound 3, percent of the compound remaining: 99.7%
Beside the measured number, compound 3's estimate is 17.7 percentage points below it; low and high end bracket the measured number.
By their numbers in this assay, from the lowest: compound 1; then compounds 3 and 2 (each within the scatter of the next).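

Hydrogen in place of ethyl on a saturated chain carbon bound to an amine nitrogen, also read as propyl to methyl, gives a number 0.3 percentage points lower from compound 2 to compound 3 (within the scatter) in this assay, so this shortening of the chain leaves the read-out within the scatter for this pair. The other new step, a number 47.5 percentage points higher from compound 1 to compound 3 (beyond the scatter), is a change on an aromatic carbon, where the group of 6 heavy atoms replaces the group of 9 heavy atoms. No evidence on the cause of either step is at hand. Going by these compounds, how a longer chain such as butyl, or a cyclopropyl group, would read at the chain position stays open, as does an acetyl group on the ring nitrogen of the group of 6 heavy atoms.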